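Chloro on the Phenoxy Ring of Compound 1

A few compounds are considered here, and "the series" means these few. Any claim that something is new, unique, unknown or untested is made for them only; others in the source may bear on it.

The measured compounds: compound 1 `Cn1c(CN2C[C@@H]3C(COc4ccccc4)[C@@H]3C2)nc2ccccc21` gives 24 nM in an in vitro assay on HEK293 cells with metabotropic glutamate receptor 2 (Rattus norvegicus) as the target, read by FLIPR, in the presence of a further agent that is not named here; a lower number here means that less compound is needed, a higher number that more compound is needed for the effect; compound 3 `c1ccc(OCC2[C@H]3CN(Cc4nc5ccccc5n4C4CC4)C[C@@H]23)cc1` gives 3020 nM in this assay. Compound 2 `c1ccc(OCC2[C@H]3CN(Cc4cn5ccccc5n4)C[C@@H]23)cc1` gives only a limit of this assay, > 10000 nM.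

Compound 1 stands lowest of the two numbers shown; its nearest neighbour is compound 3, and the step of a 130-fold higher number from compound 1 to compound 3 (2.10 log units; beyond the scatter) is large. Compound 2 sits at the limit of > 10000 nM in this assay, at which 1 of the 3 values shown sits. Compound 4 `Cn1c(CN2C[C@@H]3C(COc4ccc(Cl)cc4)[C@@H]3C2)nc2ccccc21` differs from compound 1 by chloro in place of hydrogen on an aromatic carbon. Within the data shown here, the only measured step alters the group on the aromatic nitrogen of the shared core, not the phenoxy ring, so no measured step bears directly on this change. Compound 4 is therefore expected to show a step of a 1.0-fold higher number from compound 1 to compound 4 (0.02 log units; within the scatter), within the scatter. The estimated value of compound 4 is 25 nM, with a range from 8 nM to 80 nM.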

Compound 4, half-maximal effective concentration: 26 nM
The estimate for compound 4 lay 1.0-fold (0.02 log units) below the measured number; measured number inside the range.
By their numbers in this assay, from the lowest: compounds 1 and 4 (each within the scatter of the next); then compound 3. At a limit, above all of these: compound 2.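

Within this assay the first step on the phenoxy ring reads a 1.1-fold higher number from compound 1 to compound 4 (0.03 log units; within the scatter) and so differs from the large step on the aromatic nitrogen. The numbers of the two compounds cannot be told apart, so chloro is accepted on this aromatic carbon, para to a large group, in this assay. Nothing shown here gives a reason for this result.

From the compounds shown here alone, whether a methoxy group, an amine or a carboxylic acid would be accepted at this place remains open. So does whether chloro would be accepted elsewhere on the phenoxy ring.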